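Extending a Methoxy Group Toward a Larger Aromatic Tail

This account rests on a few compounds, and the source may have more. Where it says the series, first, only, none or still open, it means among the compounds named here.

Compound 1 `CCCn1ccc2cc(-c3cccnc3)cc(Cl)c2c1=O`: 631 nM
Compound 2 `CCCn1ccc2cc(-c3ccc(OC)nc3)cc(Cl)c2c1=O`: 794 nM

Of the compounds shown here, two have been measured in a functional assay on CHO cells for agonist activity at metabotropic glutamate receptor 2 (Homo sapiens), read by GTPgammaS binding; a higher number here means that more compound is needed for the effect, a lower number that less compound is needed. Compound 1 `CCCn1ccc2cc(-c3cccnc3)cc(Cl)c2c1=O` gives 631 nM. Compound 2 `CCCn1ccc2cc(-c3ccc(OC)nc3)cc(Cl)c2c1=O` gives 794 nM, the highest of the two numbers, but its nearest neighbour, compound 1, sits within the scatter of it, so the two cannot be told apart. For the measured compounds named here, the single step, a 1.3-fold higher number from compound 1 to compound 2 (0.10 log units; within the scatter), puts a methoxy in place of a hydrogen on an aromatic carbon and changes nothing beyond the scatter.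

Compound 3 `CCCn1ccc2cc(-c3ccc(OCc4cccnc4)nc3)cc(Cl)c2c1=O` has not been measured. It differs from compound 2 by pyridin-3-yl in place of hydrogen on a saturated chain carbon bound to an oxygen on an aromatic ring; read one bond further out, the methoxy becomes a (pyridin-3-yl)methoxy. Going by the values given here, no measured step adds a group of this size, so the only relevant comparison is the small, scatter-sized effect of adding the methoxy itself. A change at this position may be expected to stay modest, though the added size leaves the outcome open. For compound 3 in this assay the expected step is a 1.3-fold lower number from compound 2 to compound 3 (0.10 log units; within the scatter), and the estimate is 630 nM, ranging from 160 nM to 2500 nM.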

Compound 3, half-maximal effective concentration: 316 nM
For compound 3 the middle estimate is 2.0-fold (0.30 log units) above the measured one; the range from low to high includes it.
By their numbers in this assay, from the lowest: compounds 3, 1 and 2 (each within the scatter of the next, the first and the last beyond it).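

In this assay, this position accepts far more than a methoxy: the much larger (pyridin-3-yl)methoxy, with its six-membered aromatic ring, brings no loss of activity. Indeed, a 2.5-fold lower number from compound 2 to compound 3 (0.40 log units; beyond the scatter) is the only step shown that passes beyond the usual scatter, although it remains modest. The comparison with the compound carrying hydrogen on the same aromatic carbon calls for caution, since a 2.0-fold lower number from compound 1 to compound 3 (0.30 log units; within the scatter) stays within the scatter, so the whole (pyridin-3-yl)methoxy cannot be said to improve on hydrogen, and no supporting data are available to explain the result.

Still open, going by these compounds, is whether a phenyl in place of the pyridin-3-yl would give a similar number, which would indicate whether the ring nitrogen counts for anything. Also open, on these data alone, is whether a longer chain carrying the pyridin-3-yl, or an amine in place of that ring, would take the number clearly below those of both compound 1 and compound 2.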